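Swapping an amino for a bromo on the pendant ring

A few compounds are considered here, and "the series" means these few. Any claim that something is new, unique, unknown or untested is made for them only; others in the source may bear on it.

For the measured compounds named here, compound 1 `Nc1cccc(CNc2cc(C(F)(F)F)cc3[nH]ncc23)c1` is one of three compounds measured in an assay for inhibition of Indoleamine 2,3-dioxygenase 1 (Homo sapiens), with stated times of 10 min and 60 min, tested at 100 uM; a higher number here means a stronger effect of the compound at the concentration tested, a lower number a weaker effect. Compound 1 gives 55%, the second highest of the three. Its nearest neighbour, compound 2 `O=[N+]([O-])c1ccccc1CNc1cc(C(F)(F)F)cc2[nH]ncc12`, gives 76%, while compound 3 `CC(C)n1ncc2c(NCc3ccccc3[N+](=O)[O-])cc(C(F)(F)F)cc21` gives 13%, the lowest of the set. Going by the values given here, the only single-place step among them runs a number 63 percentage points lower from compound 2 to compound 3 (beyond the scatter), and it concerns the hydrogen on an aromatic nitrogen of the shared core, not the pendant ring.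

Compound 4 `FC(F)(F)c1cc(NCc2cccc(Br)c2)c2cn[nH]c2c1` has not yet been measured. It differs from compound 1 in one place: bromo in place of amino on an aromatic carbon. Among the compounds with values here, no measured step touches this position or this kind of exchange, so nothing in the three numbers says whether a bromo will pull the inhibition up or down. The safest expectation is therefore a step in this assay of roughly a number 3 percentage points higher from compound 1 to compound 4 (within the scatter), meaning no change beyond the scatter, with a wide margin on either side. On that basis compound 4 is estimated at 58%, likely falling between 30% and 85%.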

Compound 4, a percentage reported as inhibition, at one concentration (the size of the read-out at that concentration, not a potency): 51%
Beside the measured number, compound 4's estimate is 7 percentage points above it, and the stated range covers the measured number.
By their numbers in this assay, from the lowest: compound 3; then compounds 4 and 1 (each within the scatter of the next); then compound 2.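

Exchanging 3-aminophenyl for 3-bromophenyl gives a number 4 percentage points lower from compound 1 to compound 4 (within the scatter) in this assay, the first step shown that touches this position on the pendant ring. The amino group, with its hydrogen-bond donor and acceptor, can therefore give way to a bromo, which has neither, with no change beyond the scatter at the one concentration tested. Nothing available explains why these two groups read alike.

As far as these compounds go, it remains open how other groups on this aromatic carbon would read, such as a carboxylic acid, a methoxy group or a longer chain, and whether any of them would move the inhibition beyond the scatter. Also open, from the compounds shown here alone, is whether the bromo would read the same elsewhere on the pendant ring, or with an isopropyl on the aromatic nitrogen of the shared core.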